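The source may report more compounds than this note shows. Statements on the series, on what has been measured and on what is new or still open speak of the compounds shown alone.

Measured so far:
- compound 1, `COc1cc(C)cc(-c2c(-c3ccnc(-c4ccc(C(C)=O)cc4)c3)cnn2CC#N)c1`: 102%
- compound 2, `COc1cc(C)cc(-c2nn(CC#N)cc2-c2ccc(-c3cccc(C(C)=O)c3)nc2)c1`: 99%

Of the compounds shown here, two sharing one core have been tested in a functional assay on OVCAR-4 cells (Homo sapiens) for cytotoxicity, read by sulforhodamine B assay, with a stated time of 48 h, tested at 0.001 uM; on this read-out lower numbers stand for a stronger effect and higher numbers for a weaker effect at the one concentration tested. Compound 1 gives 102% in this assay, and compound 2 gives 99%. Compound 1 stands highest of the two numbers, but the nearest number, that of compound 2, lies only a little lower, within the scatter, so the two values show no difference that can be trusted.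

The piece now turns from compound 1 to compound 3, `COc1cc(C)cc(-c2c(-c3ccnc(-c4ccc(N(C)C)cc4)c3)cnn2CC#N)c1`, which has not yet been measured in this assay. The change is dimethylamino in place of acetyl on an aromatic carbon, placed on an aromatic carbon of a six-membered aromatic ring of carbon only, para to a large group. For the measured compounds named here, no step between measured compounds is known for a change of this kind, so nothing in the numbers points in either direction. Since compound 1 gives 102% and compound 2 a value within the scatter of it, compound 3 is expected to give 99% in this assay, in the range 86% to 110%, and the step of a number 3 percentage points lower from compound 1 to compound 3 (within the scatter) is expected to be no larger than the scatter.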

Compound 3, a percentage reported as activity, at one concentration (the size of the read-out at that concentration, not a potency): 92%
Beside the measured number, compound 3's estimate is 7 percentage points above it, within the range that was stated.
By their numbers in this assay, from the lowest: compounds 3, 2 and 1 (each within the scatter of the next).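

For the compounds shown here, compound 3 gives the first step in which only the group on this aromatic carbon, para to a large group, is exchanged: in this assay, dimethylamino in place of acetyl gives a number 10 percentage points lower from compound 1 to compound 3 (within the scatter). Going by these compounds alone, compounds 1 and 2 could not show this, since they differ in more than one place and no step between them could be read. The new step shows that, at the one concentration tested, this read-out does not separate 4-acetylphenyl from 4-(dimethylamino)phenyl, even though the exchange replaces a group with a carbonyl by one with an amine nitrogen; no measurement is available that could explain this result.

The compounds shown leave open whether a carboxylic acid, a primary amine or a longer alkyl chain on this carbon would give a step beyond the scatter. They also leave open whether acetyl and dimethylamino would separate at another concentration, and whether the same exchange would give a similar step on the core of compound 2.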